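A few compounds are considered here, and "the series" means these few. Any claim that something is new, unique, unknown or untested is made for them only; others in the source may bear on it.

In a functional assay on A549 cells (Homo sapiens) for cytotoxicity, read by MTT assay, with a stated time of 72 h (on this read-out higher numbers stand for weaker inhibition and lower numbers for stronger inhibition), compound 1 `CN(C)Cc1ccc2nc(NC(=O)N/N=C/c3c[nH]c4ccccc34)sc2c1`, with hydrogen on the aromatic nitrogen, gives 3300 nM. Compound 2 `CN(C)Cc1ccc2nc(NC(=O)N/N=C/c3cn(Cc4ccc(Cl)cc4)c4ccccc34)sc2c1` gives 840 nM, and compound 3 `Cc1ccc(Cn2cc(/C=N/NC(=O)Nc3nc4ccc(CN(C)C)cc4s3)c3ccccc32)cc1` gives 1600 nM. Compound 3 thus lies within the scatter of compound 2 but clearly below compound 1, as a 1.9-fold higher number from compound 2 to compound 3 (0.28 log units; within the scatter) and a 2.1-fold lower number from compound 1 to compound 3 (0.31 log units; beyond the scatter) show.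

Compound 4 `CN(C)Cc1ccc2nc(NC(=O)N/N=C/c3cn(Cc4ccc(Cl)c(Cl)c4)c4ccccc34)sc2c1` has 3,4-dichlorophenyl in place of the 4-methylphenyl of compound 3, on a saturated chain carbon bound to an aromatic nitrogen: 3,4-dichlorophenyl in place of 4-methylphenyl on a saturated chain carbon bound to an aromatic nitrogen. The nearest guide is compound 2, which also carries chloro, and its link to compound 3 is a 1.9-fold higher number from compound 2 to compound 3 (0.28 log units; within the scatter). The largest measured step, a 3.9-fold lower number from compound 1 to compound 2 (0.59 log units; beyond the scatter), also leads to compound 2. For the measured compounds named here, no measured compound carries two chloro groups, so the effect of the second one remains open. A modest move towards a lower number in this assay is expected, a 2.1-fold lower number from compound 3 to compound 4 (0.33 log units; beyond the scatter). The estimated value for compound 4 is 750 nM, with an expected range of 280 nM to 2000 nM.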

Compound 4, half-maximal inhibitory concentration: 940 nM
The estimate for compound 4 lay 1.3-fold (0.10 log units) below the measured number; measured number inside the range.
By their numbers in this assay, from the lowest: compounds 2, 4 and 3 (each within the scatter of the next); then compound 1.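

At this aromatic nitrogen in this assay, 3,4-dichlorobenzyl also separates from hydrogen, with a 3.5-fold lower number from compound 1 to compound 4 (0.55 log units; beyond the scatter), so all three benzyl groups shown now lie beyond the scatter of compound 1. Adding a second chloro gives no readable change, with a 1.1-fold higher number from compound 2 to compound 4 (0.05 log units; within the scatter), and replacing 4-methylphenyl with 3,4-dichlorophenyl also stays within the scatter, with a 1.7-fold lower number from compound 3 to compound 4 (0.23 log units; within the scatter), so this assay does not tell these benzyl groups apart. Nothing available bears on why these groups give such similar numbers.

Going by these compounds, it remains open whether a longer alkyl chain on this nitrogen, or a benzyl group whose ring carries an amine or a carboxylic acid, would give a similar number. On these data alone, the shared core is the same in all four compounds, so the effect of changes there also remains open.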